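The source may hold more compounds than are shown below. What is called first, only, known or untested is meant among the compounds shown, and "the series" means these compounds.

In an ADME assay on HEK293 cells (Homo sapiens) for cytotoxicity, read by MTT assay, with a stated time of 24 h (on this read-out lower numbers stand for stronger inhibition and higher numbers for weaker inhibition), compound 1 `CN(C)CCCCNc1nc2cc([N+](=O)[O-])ccc2nc1NCc1ccc(C(F)(F)F)cc1` gives 9.73 ug/mL. Compound 2 `O=[N+]([O-])c1ccc2nc(NCc3ccc(C(F)(F)F)cc3)c(N3CCCCC3)nc2c1` gives > 200 ug/mL, which is a limit of the assay and not a number. Compound 3 `CN(C)CCCNc1nc2cc([N+](=O)[O-])ccc2nc1NCc1ccc(Br)cc1` gives 9.63 ug/mL, within the scatter of compound 1, and these two share the low end of the numbers. Compound 4 `CN(C)CCCNc1nc2cc([N+](=O)[O-])ccc2nc1NCc1ccccc1Br` differs from compound 3 as follows: 2-bromophenyl in place of 4-bromophenyl on a saturated chain carbon bound to a nitrogen on an aromatic ring. Going by the values given here, the one measured step, an at least 20-fold higher number from compound 1 to compound 2 (1.31 log units; beyond the scatter), is large, but it lies at a different place and involves no bromine, so it sets no size for this change. No step beyond the scatter is therefore expected in this assay. The expected change is a 1.0-fold higher number from compound 3 to compound 4 (0.02 log units; within the scatter). Compound 4 is estimated at 10 ug/mL, with an expected range of 4.5 ug/mL to 25 ug/mL.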

Compound 4, half-maximal inhibitory concentration: 51.9 ug/mL
Compound 4: the middle estimate sits 5.2-fold (0.72 log units) below what was measured; the measured number lies above the stated range.
By their numbers in this assay, from the lowest: compounds 3 and 1 (each within the scatter of the next); then compound 4. At a limit, above all of these: compound 2.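

In this assay, 2-bromophenyl in place of 4-bromophenyl gives a 5.4-fold higher number from compound 3 to compound 4 (0.73 log units; beyond the scatter) with the same atoms joined differently. This is the first step shown on a saturated chain carbon bound to a nitrogen on an aromatic ring, and it shows that the number here responds to where the bromine sits on the phenyl ring, not only to which atoms are present.

On these data alone, whether chlorine or a methoxy group in place of the bromine would give a step of like size stays open. No measured property shown bears on the reason for this step.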